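Fluoro on the phenyl of a cytotoxicity series

The source may report more compounds than this note shows. Statements on the series, on what has been measured and on what is new or still open speak of the compounds shown alone.

Measured compounds:
compound 1 `O=C(Nc1nc2ccccc2s1)c1cn(-c2ccccc2)nc1-c1ccccc1` — > 50000 nM
compound 2 `O=C(Nc1nc2ccc(Cl)cc2s1)c1cn(-c2ccccc2)nc1-c1ccccc1` — 21300 nM
compound 3 `Cc1ccc2nc(NC(=O)c3cn(-c4ccccc4)nc3-c3ccccc3)sc2c1` — > 50000 nM

In an ADME assay on HEK-293T cells (Homo sapiens) for cytotoxicity, read by MTT assay, with a stated time of 72 h (a lower number here means a stronger inhibitor, a higher number a weaker inhibitor), compound 1 gives > 50000 nM, which is a limit of the assay and not a number. Compound 3 also gives > 50000 nM, again a limit. Compound 2 is the only one of the three with a read number, 21300 nM. The step from compound 1 to compound 2 is an at least 2.3-fold lower number from compound 1 to compound 2 (0.37 log units; beyond the scatter), the step from compound 2 to compound 3 is an at least 2.3-fold higher number from compound 2 to compound 3 (0.37 log units; beyond the scatter), and the step from compound 1 to compound 3 is a step that the two limits leave unreadable from compound 1 to compound 3. Two of the three values sit at the limit of > 50000 nM in this assay, at which 2 of the 3 values shown sit.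

Compound 4 `O=C(Nc1nc2ccccc2s1)c1cn(-c2ccccc2)nc1-c1ccc(F)cc1` differs from compound 1 in this way: fluoro in place of hydrogen on an aromatic carbon. Going by the values given here, none of the measured steps touches the same ring: chloro and methyl were set on the fused part of the shared core, whereas the fluoro of compound 4 sits on the phenyl. The nearest comparison is the halogen step from compound 1 to compound 2, which read an at least 2.3-fold lower number from compound 1 to compound 2 (0.37 log units; beyond the scatter), but a fluoro on a different ring need not follow it. Compound 4 is therefore expected to stay near the limit in this assay, an estimated step of an at least 1.1-fold lower number from compound 1 to compound 4 (0.04 log units; that floor lies within the scatter). The estimate for compound 4 is 45000 nM, between 15000 nM and 150000 nM.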

Compound 4, half-maximal inhibitory concentration: 33400 nM
Compound 4: the middle estimate sits 1.3-fold (0.13 log units) above what was measured, within the range that was stated.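

In this assay, the change from phenyl to 4-fluorophenyl is the first step shown on a phenyl ring, whereas the chloro of compound 2 and the methyl of compound 3 sit elsewhere on the shared core. This single fluoro, para to a large group, gives an at least 1.4-fold lower number from compound 1 to compound 4 (0.17 log units; that floor lies within the scatter), so compound 4 has a read number where compound 1 has only a limit, but the floor of this step does not establish a change beyond the scatter. The true size of the step stays unknown because the value of compound 1 is a limit that recurs in this series: the limit of > 50000 nM in this assay, at which 2 of the 4 values shown sit.

The compounds shown leave open whether a larger group on this phenyl, such as trifluoromethyl or methoxy, or an amine or a carboxylic acid in the same place, would give a clear move in this cytotoxicity read-out. They also leave open whether the fluoro of compound 4 and the chloro of compound 2, carried together on one molecule, would give a lower number than either change alone.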